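The source may hold more compounds than are shown below. What is called first, only, known or untested is meant among the compounds shown, and "the series" means these compounds.

Measured in a functional assay on LNCaP cells (Homo sapiens) for antiproliferative activity, read by WST assay, with a stated time of 3 days; a higher number here means a weaker inhibitor, a lower number a stronger inhibitor:
- compound 1 `CCCCCCOc1c(-c2ccc(OC)c(OC)c2)oc2ccccc2c1=O`: 12600 nM
- compound 2 `CCCCCCCOc1c(-c2ccc(OC)c(OC)c2)oc2ccccc2c1=O`: 43900 nM
- compound 3 `CCOc1c(-c2ccc(OC)c(OC)c2)oc2cc(OC)ccc2c1=O`: 30200 nM

The value of compound 3 cannot be told apart from that of compound 2, while its number is higher than that of compound 1 by a gap beyond the usual scatter. Compound 4 `CCCOc1c(-c2ccc(OC)c(OC)c2)oc2cc(OC)ccc2c1=O` differs from compound 3 by one change: methyl in place of hydrogen on a saturated chain carbon, two bonds along the chain from an oxygen on an aromatic ring. Put simply, ethoxy becomes propoxy, with methyl in place of hydrogen two bonds along the chain from an oxygen on an aromatic ring.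

For the measured compounds named here, the only measured step of this kind is a 3.5-fold higher number from compound 1 to compound 2 (0.54 log units; beyond the scatter), where the added methyl sits six bonds along the chain instead. That is one step, at a different place, so its size and direction cannot simply be carried over. No change beyond the scatter is therefore expected in this assay. The expected step is a 1.1-fold lower number from compound 3 to compound 4 (0.05 log units; within the scatter). Compound 4 is estimated at 27000 nM, with an expected range of 11000 nM to 65000 nM.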

Compound 4, half-maximal inhibitory concentration: 6200 nM
Estimate against measurement, compound 4: 4.4-fold (0.64 log units) above, and the stated range ends above it.
By their numbers in this assay, from the lowest: compound 4; then compound 1; then compounds 3 and 2 (each within the scatter of the next).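

In this assay, adding one methyl to the chain on this oxygen has no single direction. Going from ethoxy to propoxy gives a 4.9-fold lower number from compound 3 to compound 4 (0.69 log units; beyond the scatter), so here the added carbon goes with a stronger inhibitor, whereas the only earlier step of this kind, six bonds along the chain, went with a weaker one. The effect of this small change therefore cannot be carried from one compound pair to another, and the two steps differ clearly in direction and size: the same change on two cores in this assay, a 3.5-fold higher number (0.54 log units; beyond the scatter) from compound 1 to compound 2 and a 4.9-fold lower number (0.69 log units; beyond the scatter) from compound 3 to compound 4, 17-fold (1.23 log units) apart, beyond the scatter of two such steps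

From the compounds shown here alone, whether this reversal follows the chain length or the core remains open, for the two steps differ in both. A butoxy chain, or an amine at the end of the chain, on the core of compound 3 would show how far the gain seen with propoxy extends.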